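A smaller group on the ring of compound 3

The source may hold more compounds than are shown below. What is called first, only, known or untested is meant among the compounds shown, and "the series" means these compounds.

Measured in an ADME assay on L1210/0 cells (Mus musculus) for cytotoxicity, with a stated time of 48 h; a lower number here means a stronger inhibitor, a higher number a weaker inhibitor:
compound 1 `O[C@H]1C[C@@H](Cn2cnc3c(-c4ccccc4)ncnc32)c2ccccc21`: > 200000 nM (a limit of the assay, not a number)
compound 2 `[N-]=[N+]=NCc1cn([C@H]2C[C@H](O)[C@@H](CO)O2)c(=O)[nH]c1=O`: 124000 nM
compound 3 `O=C(CI)NCc1cn([C@H]2C[C@H](O)[C@@H](CO)O2)c(=O)[nH]c1=O`: 107000 nM

Among the measured compounds shown here, compound 3 stands within the scatter of compound 2, and these are the only two exact numbers in this assay. For the measured compounds named here, the single measured step, a 1.2-fold lower number from compound 2 to compound 3 (0.06 log units; within the scatter), put ((iodomethyl)carbonyl)amino in place of azido on a saturated chain carbon bound to an aromatic carbon. Compound 4 `C[S+]([O-])c1cn([C@H]2C[C@H](O)[C@@H](CO)O2)c(=O)[nH]c1=O` has not been measured, and its change is a group of 3 heavy atoms (1 carbon, 1 oxygen, 1 sulfur; no ring) in place of a group of 6 heavy atoms (3 carbon, 1 nitrogen, 1 oxygen, 1 iodine; no ring), on an aromatic carbon, on an aromatic carbon. That change removes the whole group altered in the measured step, so the step is only a loose guide. No step beyond the scatter is expected. The expected step is a 1.3-fold higher number from compound 3 to compound 4 (0.12 log units; within the scatter). For compound 4 the estimate is 140000 nM, with an expected range from 50000 nM to 300000 nM.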

Compound 4, half-maximal inhibitory concentration: > 200000 nM
Compound 4 ended at the assay's limit; the forecaster's own chance of this, stated with the estimate: 35%; at least 1.4-fold (0.15 log units) between middle value and limit.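

In this assay, among the compounds shown here, the earlier compounds showed only groups joined through a saturated chain carbon on this aromatic carbon, and compound 4 carries a smaller group attached directly. The readings are an at least 1.8-fold higher number from compound 3 to compound 4 (0.27 log units; that floor lies within the scatter) and an at least 1.6-fold higher number from compound 2 to compound 4 (0.20 log units; that floor lies within the scatter), so the change gives no floor beyond the scatter. Compound 4 gives a limit, not a number: the limit of > 200000 nM in this assay, at which 2 of the 4 values shown sit.

From the compounds shown here alone, how far compound 4 really lies from the other two remains open. So does whether an amine or a carboxylic acid on this aromatic carbon would give a number clearly apart from compound 3.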